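A few compounds are considered here, and "the series" means these few. Any claim that something is new, unique, unknown or untested is made for them only; others in the source may bear on it.

Two compounds of this series have numbers in an assay on isolated protein for inhibition of Rho-associated protein kinase 2 (Homo sapiens), read by scintillation counting, radiometric assay and 33P incorporation, with a stated time of 40 min, in the presence of a further agent that is not named here; on this read-out higher numbers stand for weaker inhibition and lower numbers for stronger inhibition. Compound 1 `COc1ccc(OCC(=O)Nc2cccc(NC(=O)c3ccc(N(C)C)cc3)c2)cc1F` gives 652 nM in this assay. Among the measured compounds shown here, compound 2 `CCCC(=O)Nc1cccc(NC(=O)COc2ccc3c(=O)ccoc3c2)c1` gives 176 nM in this assay, the lower of the two numbers, and the gap to compound 1 lies beyond the scatter; the two structures differ in more than one place, so no single step is read from them.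

Compound 3 `Cc1nc(C(=O)Nc2cccc(NC(=O)COc3ccc4c(=O)ccoc4c3)c2)cs1` has not been measured. It differs from compound 2 in one place: 2-methyl-1,3-thiazol-4-yl in place of propyl on a carbonyl carbon. For the measured compounds named here, no measured pair shows this change, so the expectation rests on the amide variation between compound 1 and compound 2 alone, which offers no direct guide.

For compound 3 the step of a 1.1-fold higher number from compound 2 to compound 3 (0.06 log units; within the scatter) is expected to fall within the scatter. In this assay compound 3 is estimated at 200 nM, with a range from 70 nM to 600 nM.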

Compound 3, half-maximal inhibitory concentration: 33 nM
Compound 3: the middle estimate sits 6.1-fold (0.78 log units) above what was measured; measured number below the stated range.
By their numbers in this assay, from the lowest: compound 3; then compound 2; then compound 1.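

Among the compounds shown here, on the carbonyl carbon whose other neighbour is the amide-type nitrogen, putting 2-methyl-1,3-thiazol-4-yl in place of propyl gives a 5.3-fold lower number from compound 2 to compound 3 (0.73 log units; beyond the scatter) in this assay as the first single-place step. The position therefore responds to the group it carries, which the gap between compound 1 and compound 2 could not show, as those two differ in more than one place. The entering group adds a five-membered aromatic ring with 2 hetero atoms, but no available data bear on why the number falls.

On these data alone, one step does not separate the methyl from the thiazole ring, so it remains open whether the unsubstituted thiazole, a phenyl ring or a longer alkyl chain on this carbonyl carbon would give a similar number. Also open, as far as these compounds go, is whether the same change would carry over to the core of compound 1.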